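Side-chain extension from compound 2 to compound 3

The source may hold more compounds than are shown below. What is called first, only, known or untested is meant among the compounds shown, and "the series" means these compounds.

Going by the values given here, in a functional assay on HeLa cells (Homo sapiens) for antiproliferative activity, read by MTT assay, with a stated time of 48 h (a lower number here means a stronger inhibitor, a higher number a weaker inhibitor), compound 1 `CCN(CC)CCCn1c(N)c(-c2nc3ccccc3n2C)c2nc(C#N)c(C#N)nc21` gives 12400 nM and holds the only numerical value so far. Compound 2 `CCN(CC)CCn1c(N)c(-c2nc3cc(Cl)ccc3[nH]2)c2nc(C#N)c(C#N)nc21` is recorded at > 50000 nM in this assay and this entry is a limit of the assay, not a number.

Compound 3 `CCN(CC)CCCn1c(N)c(-c2nc3cc(Cl)ccc3[nH]2)c2nc(C#N)c(C#N)nc21` changes only the side chain of compound 2: (diethylamino)methyl in place of diethylamino on a saturated chain carbon, two bonds along the chain from an aromatic nitrogen. In words, (diethylamino)methyl stands in place of diethylamino on a saturated chain carbon, two bonds along the chain from an aromatic nitrogen. Cut one bond further out, this reads as 2-(diethylamino)ethyl to 3-(diethylamino)propyl.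

Among the compounds with values here, no measured step shows the effect of this change. Compound 3 carries the same 3-(diethylamino)propyl chain as compound 1, which gives 12400 nM and is the only basis for expecting a measurable number. The expected step is an at least 2.2-fold lower number from compound 2 to compound 3 (0.35 log units; beyond the scatter) and it runs toward stronger inhibition, although a result at the limit remains possible. Compound 3 is estimated at 22000 nM with an expected range of 8000 nM to 50000 nM in this assay for now.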

Compound 3, half-maximal inhibitory concentration: 24400 nM
The estimate for compound 3 lay 1.1-fold (0.04 log units) below the measured number; the measured number falls inside the stated range.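

In this assay, 3-(diethylamino)propyl in place of 2-(diethylamino)ethyl gives an at least 2.0-fold lower number from compound 2 to compound 3 (0.31 log units; beyond the scatter), the only step shown that leads from a limit to a number and the first direct reading of this chain change with the rest of the structure held constant. The entry for compound 2 is a limit of the assay and not a number, so the step has a lower bound and no exact size: the limit of > 50000 nM in this assay, at which 1 of the 3 values shown sits. With the 3-(diethylamino)propyl chain held constant, 5-chloro-1H-benzimidazol-2-yl in place of 1-methyl-1H-benzimidazol-2-yl gives a 2.0-fold higher number from compound 1 to compound 3 (0.29 log units; within the scatter), so this assay does not separate these two groups on an aromatic carbon.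

The compounds shown leave open whether a longer chain such as 4-(diethylamino)butyl would continue the trend, and whether the diethylamino end can give way to a dimethylamino or a morpholine group with the same result. They also leave open whether the chain step holds with 1-methyl-1H-benzimidazol-2-yl, since the step rests on a single pair carrying 5-chloro-1H-benzimidazol-2-yl.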